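The source may hold more compounds than are shown below. What is called first, only, known or untested is meant among the compounds shown, and "the series" means these compounds.

In a physicochemical assay for lipophilicity, read by HPLC, at pH 7.5 (a higher number here means a more lipophilic compound, a lower number a more polar compound), compound 3 `CCCCC(Nc1c(C#N)c(-c2ccc(-c3ccccc3OCC)cc2)nc2cnccc12)C(N)=O` gives 3.6, the highest of three measured numbers. Compound 2 `CC[C@@H](Nc1c(C#N)c(-c2ccc(-c3ccccc3N(C)C)cc2)nc2cnccc12)C(N)=O` gives 3.2 and compound 1 `CC[C@@H](Nc1c(C#N)c(-c2ccc(-c3ccc(OC)cc3)cc2)nc2cnccc12)C(N)=O` gives 2.7. Compound 4 `CCOc1ccccc1-c1ccc(-c2nc3cnccc3c(N[C@H](CC)C(N)=O)c2C#N)cc1` is still unmeasured, and it differs from compound 3 in one place: 1-carbamoylpropyl in place of 1-carbamoylpentyl on a nitrogen on an aromatic ring. Among the measured compounds shown here, the one measured step, a number 0.50 log units higher from compound 1 to compound 2 (beyond the scatter), comes from a different change, 2-(dimethylamino)phenyl in place of 4-methoxyphenyl, so no measured step tests this swap directly. Still, compound 1 at 2.7 and compound 2 at 3.2 already carry 1-carbamoylpropyl, and both read lower than compound 3, although they differ from it elsewhere too. The expected change is therefore downward and beyond the scatter, a number 0.60 log units lower from compound 3 to compound 4 (beyond the scatter). For compound 4 the estimated value is 3, with an expected range from 2.7 to 3.3.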

Compound 4, distribution coefficient: 3
Compound 4: the middle estimate sits on the measured number at the digits printed; the range from low to high includes it.
By their numbers in this assay, from the lowest: compounds 1, 4 and 2 (each within the scatter of the next, the first and the last beyond it); then compound 3.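

In this assay the swap on the nitrogen now has a direct reading: 1-carbamoylpropyl in place of 1-carbamoylpentyl gives a number 0.60 log units lower from compound 3 to compound 4 (beyond the scatter) with the rest of the molecule unchanged. With 1-carbamoylpropyl held constant, a number 0.20 log units lower from compound 2 to compound 4 (within the scatter) for ethoxy in place of dimethylamino and a number 0.30 log units higher from compound 1 to compound 4 (within the scatter) for 2-ethoxyphenyl in place of 4-methoxyphenyl show that these two aryl swaps cannot be told apart here. No measured evidence explains these readings.

From the compounds shown here alone, what a chain longer than 1-carbamoylpentyl, or a carboxylic acid or an amine in place of the carbamoyl group, would read on this nitrogen remains open.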